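Replacing a Chlorophenyl Arm with a Benzyloxy Group

The source may report more compounds than this note shows. Statements on the series, on what has been measured and on what is new or still open speak of the compounds shown alone.

Compound 3 `Cc1ccc(CN2C(=O)S/C(=C\c3ccc(Cl)cc3)C2=O)cc1` stands lowest of the three compounds measured in a functional assay on the whole organism (plasma) with Mus musculus as the target, with a stated time of 15 days, at a dose of 30 mg/kg by the oral route (a lower number here means a weaker effect, a higher number a stronger effect of the compound at the dose given), where compound 3 gives 22.8%. Compound 1 `COc1ccc(/C=C2\SC(=O)N(Cc3ccc(C)cc3)C2=O)cc1` gives 50.8% and compound 2 `Cc1ccc(CN2C(=O)S/C(=C\c3ccccc3Cl)C2=O)cc1` gives 43.3%. The step from compound 1 to compound 3 was a number 28 percentage points lower from compound 1 to compound 3 (beyond the scatter), and the step from compound 2 to compound 3 was a number 20.5 percentage points lower from compound 2 to compound 3 (beyond the scatter). Compound 4 `Cc1ccc(CN2C(=O)S/C(=C\OCc3ccccc3)C2=O)cc1` arises from compound 3 through (benzyloxy in place of 4-chlorophenyl on a double-bonded chain carbon bound to a double-bonded ring carbon). Going by the values given here, no measured step tests a benzyloxy group itself; the two steps into compound 3 only show that the 4-chlorophenyl group sat at the bottom of this small set. For compound 4 an upward move in this assay is therefore expected, of the size a number 12.2 percentage points higher from compound 3 to compound 4 (beyond the scatter), with wide uncertainty. Compound 4 is estimated at 35%, between 15% and 58%.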

Compound 4, a percentage reported as activity, at one dose (the size of the read-out at that dose, not a potency): 20.2%
The estimate for compound 4 lay 14.8 percentage points above the measured number; low and high end bracket the measured number.
By their numbers in this assay, from the lowest: compounds 4 and 3 (each within the scatter of the next); then compounds 2 and 1 (each within the scatter of the next).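

Putting benzyloxy on the double-bonded chain carbon in place of 4-chlorophenyl gives a number 2.6 percentage points lower from compound 3 to compound 4 (within the scatter) in this assay, so the two groups cannot be told apart here. Against the other two arms, benzyloxy gives a number 23.1 percentage points lower from compound 2 to compound 4 (beyond the scatter) and a number 30.6 percentage points lower from compound 1 to compound 4 (beyond the scatter) in this assay, so the higher numbers stay with 2-chlorophenyl and 4-methoxyphenyl. No measurement here explains these differences.
On these data alone, whether an amine or a carboxylic acid at this place would match compound 1 remains open. So does whether a longer chain ending in the same phenyl ring would behave like benzyloxy.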